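From hydroxy to (but-3-en-1-yl)oxy on an aromatic ring

The source may report more compounds than this note shows. Statements on the series, on what has been measured and on what is new or still open speak of the compounds shown alone.

In a functional assay on SK-MEL-28 cells (Homo sapiens) for inhibition, read by colorimetric assay and MTT assay, with a stated time of 72 h (a lower number here means a stronger inhibitor, a higher number a weaker inhibitor), compound 3 `Cn1c(-c2ccccc2O)cnc1S(=O)(=O)c1ccccc1` stands at > 100000 nM, which is a limit and not a number. The change to compound 4 `C=CCCOc1ccccc1-c1cnc(S(=O)(=O)c2ccccc2)n1C` is but-3-en-1-yl in place of hydrogen on an oxygen on an aromatic ring, turning hydroxy into (but-3-en-1-yl)oxy. Compound 1 `C=CCCCCOc1ccccc1-c1cnc(OCCCCC=C)n1C` gives 5000 nM and compound 2 `C=CCCCCOc1ncc(-c2ccccc2OC)n1C` gives 13000 nM, so both carry measured numbers in this assay. The nearest measured change removes pent-4-en-1-yl from a chain on an oxygen, a 2.6-fold higher number from compound 1 to compound 2 (0.41 log units; beyond the scatter). Among the measured compounds shown here, no measured step adds a chain to a free hydroxy, so this comparison is only indirect. A longer chain went with a lower number there, so a lower number is expected here, and the expected step is an at least 5.0-fold lower number from compound 3 to compound 4 (0.69 log units; beyond the scatter). For compound 4 the estimate is 20000 nM, with an expected range of 5000 nM to 90000 nM.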

Compound 4, half-maximal inhibitory concentration: 60000 nM
For compound 4 the middle estimate is 3.0-fold (0.48 log units) below the measured one, within the range that was stated.
By their numbers in this assay, from the lowest: compound 1; then compound 2; then compound 4. At a limit, above all of these: compound 3.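

Putting but-3-en-1-yl on the oxygen of the free hydroxy gives an at least 1.6-fold lower number from compound 3 to compound 4 (0.22 log units; that floor lies within the scatter) in this assay and turns an open-ended reading into a measured one. The size of that step is only a floor, so it cannot by itself show a change beyond the scatter. Compound 3 stands at a limit and not a number: the limit of > 100000 nM in this assay, at which 1 of the 4 values shown sits.

Going by these compounds, how large the true step is remains open. So does whether a chain ending in an amine or a carboxylic acid on this oxygen would give a lower number.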